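The source may report more compounds than this note shows. Statements on the series, on what has been measured and on what is new or still open speak of the compounds shown alone.

Working notes on the series. In a functional assay on cardiac atrium for agonist activity at histamine H2 receptor (Cavia porcellus) (a lower number here means a less potent compound, a higher number a more potent compound, by a factor of ten per unit of this negative logarithm), compound 3 `N=C(NCCCc1c[nH]cn1)NCCCC(c1ccc(Cl)c(Cl)c1)c1ccccn1` gives 6.67, compound 1 `CN/C(=N\CCC(c1ccc(F)cc1)c1ccccn1)NCCCc1c[nH]cn1` gives 5.65, and compound 2 `c1ccc(C(CCC/N=C(/NCCCc2c[nH]cn2)NC2CCCCC2)c2ccccn2)cc1` gives 4.49. Compound 2 thus stands lowest of the three numbers recorded in this assay; the nearest is compound 1, whose value lies above it beyond the scatter, and the furthest is compound 3, further above it and also beyond the scatter. Among the measured compounds shown here, no pair of measured compounds differs in a single place, so no measured step is available to anchor the change that follows.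

Compound 4 `Clc1ccc(C(CCC/N=C(/NCCCc2c[nH]cn2)NC2CCCCC2)c2ccccn2)cc1Cl` has not yet been measured. It differs from compound 2 by 3,4-dichlorophenyl in place of phenyl on a saturated chain carbon bound to an aromatic carbon and a saturated chain carbon. For the measured compounds named here, compound 3 carries the same 3,4-dichlorophenyl group on its chain carbon and gives the highest number of the set, but compound 3 also differs from compound 2 elsewhere on the shared core, so the two values show only that a dichlorophenyl member can sit well above compound 2 in this assay. Compound 4 is expected to show a number 0.51 log units higher from compound 2 to compound 4 (beyond the scatter) in this assay, a moderate step upward, though one that could still fall within the scatter. The estimate for compound 4 in this assay is 5, with an expected range from 4.3 to 5.8.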

Compound 4, negative logarithm of the half-maximal effective concentration: 4.65
Beside the measured number, compound 4's estimate is 0.35 log units above it; measured number inside the range.
By their numbers in this assay, from the lowest: compounds 2 and 4 (each within the scatter of the next); then compound 1; then compound 3.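

In this assay, among the compounds shown here, the exchange of phenyl for 3,4-dichlorophenyl on a saturated chain carbon bound to an aromatic carbon and a saturated chain carbon gives a number 0.16 log units higher from compound 2 to compound 4 (within the scatter) and is the first step that can be read in one place. On the core shared by these two compounds, adding the two chlorine atoms at this position therefore leaves the functional read-out indistinguishable, so the presence of 3,4-dichlorophenyl does not by itself bring a separable difference here. No available evidence bears on why the two compounds read alike.

The compounds shown leave open whether this result holds on the core of compound 3, where a phenyl partner carrying the same side of the molecule would be needed for a one-place reading. They also leave open how this position responds on the core of compound 2 to groups of another kind, such as an amine, a carboxylic acid or a methoxy group in place of the chlorine atoms.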